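A Thiazole Gives Way to a Small Amide

The source may report more compounds than this note shows. Statements on the series, on what has been measured and on what is new or still open speak of the compounds shown alone.

Three measured compounds share one core and differ only in the group on a saturated chain carbon bound to an aromatic carbon and a saturated chain carbon. In a functional assay on CHO cells for antagonist activity at prostaglandin E2 receptor EP3 subtype (Homo sapiens), read by cAMP accumulation (a higher number here means a weaker inhibitor, a lower number a stronger inhibitor), compound 1 `CC(C)C(c1ccc(-c2ccc3cccc(F)c3c2)[nH]c1=O)N1CCCCS1(=O)=O` gives 122 nM. In this assay compound 2 `CC(C)C(Nc1nnc[nH]1)c1ccc(-c2ccc3cccc(F)c3c2)[nH]c1=O` gives 185 nM. In this assay compound 3 `CC(C)C(c1cnc(N)s1)c1ccc(-c2ccc3cccc(F)c3c2)[nH]c1=O` gives 39 nM, the lowest of the three numbers: a 3.1-fold lower number from compound 1 to compound 3 (0.50 log units; beyond the scatter) and a 4.7-fold lower number from compound 2 to compound 3 (0.68 log units; beyond the scatter), both beyond the scatter, whereas a 1.5-fold higher number from compound 1 to compound 2 (0.18 log units; within the scatter).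

Compound 4 `CC(C)C(CC(N)=O)c1ccc(-c2ccc3cccc(F)c3c2)[nH]c1=O` differs from compound 3 in one place: carbamoylmethyl in place of 2-amino-1,3-thiazol-5-yl on a saturated chain carbon bound to an aromatic carbon and a saturated chain carbon. Among the compounds with values here, the steps that bear on this are the two leading into compound 3, in which the aminothiazole took the place of a ring group in each case and lowered the number. Removing the aminothiazole in favour of a group with no ring is therefore expected to raise the number again, by about the size of those steps. The step expected in this assay is a 3.8-fold higher number from compound 3 to compound 4 (0.59 log units; beyond the scatter). Compound 4 is thus estimated at 150 nM, within a range from 50 nM to 450 nM.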

Compound 4, half-maximal inhibitory concentration: 53 nM
The estimate for compound 4 lay 2.8-fold (0.45 log units) above the measured number, within the range that was stated.
By their numbers in this assay, from the lowest: compounds 3 and 4 (each within the scatter of the next); then compounds 1 and 2 (each within the scatter of the next).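

In this assay an aromatic ring on the saturated chain carbon proves unnecessary for the lower numbers: carbamoylmethyl, which has no ring, stands level with 2-amino-1,3-thiazol-5-yl (a 1.4-fold higher number from compound 3 to compound 4 (0.13 log units; within the scatter)). The same group also improves on the two other groups, giving a clear gain over (4H-1,2,4-triazol-3-yl)amino (a 3.5-fold lower number from compound 2 to compound 4 (0.54 log units; beyond the scatter)) and a gain over the six-membered non-aromatic ring of compound 1 (a 2.3-fold lower number from compound 1 to compound 4 (0.36 log units; beyond the scatter)). Among these four compounds, then, neither a ring nor a larger group at this position goes with a lower number, since compound 1 and compound 2 both carry rings and compound 3 does too.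

Nothing shown here explains why these groups rank as they do. As far as these compounds go, it also remains open whether the primary amide itself matters, as a carboxylic acid, a methyl ester or a longer chain ending in the same amide could show.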